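Swapping a Dimethoxybenzoyl Amide for a Phenylbutanoyl Chain

A few compounds are considered here, and "the series" means these few. Any claim that something is new, unique, unknown or untested is made for them only; others in the source may bear on it.

The measured compounds are:
compound 1 `COc1ccc(C(=O)NCCCN2CCN(CCCNc3ccnc4cc(Cl)ccc34)CC2)cc1OC`, which in an ADME assay on L6 cells (Rattus norvegicus) for cytotoxicity (on this read-out higher numbers stand for weaker inhibition and lower numbers for stronger inhibition), gives "not determined" (no result reported);
compound 2 `O=C(NCCCN1CCN(CCCNc2ccnc3cc(Cl)ccc23)CC1)c1ccccc1C(=O)c1ccccc1`, which in this assay gives 3200 nM;
compound 3 `CC(C)=CC(=O)NCCCN1CCN(CCCNc2ccnc3cc(Cl)ccc23)CC1`, which in this assay gives 30000 nM.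

All three share one core carrying an amide, and they differ only in what sits on the carbonyl carbon. Compound 1 stands nowhere on the numbers shown, since no result was reported for it; the two numbers at hand come from compound 2 and compound 3, and they lie well apart from each other, with compound 3 showing the weaker inhibition.

Compound 4 `O=C(CCCCc1ccccc1)NCCCN1CCN(CCCNc2ccnc3cc(Cl)ccc23)CC1` is the next candidate. Relative to compound 1 the change is 4-phenylbutyl in place of 3,4-dimethoxyphenyl on a carbonyl carbon. Both groups are of the same count of heavy atoms and both carry one six-membered aromatic ring of carbon only; what leaves carries two hydrogen-bond acceptors, what enters carries none.

For the measured compounds named here, with no number for compound 1, no step to compound 4 can be quantified or given a direction. Going only by the span between compound 2 and compound 3, compound 4 is expected to land in between, at an estimated 8000 nM, within a range from 2500 nM to 25000 nM.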

Compound 4, half-maximal inhibitory concentration: 9400 nM
The estimate for compound 4 lay 1.2-fold (0.07 log units) below the measured number; the measured number falls inside the stated range.
By their numbers in this assay, from the lowest: compound 2; then compound 4; then compound 3.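

In this assay, the new result gives this position its first step that can be read, a 3.2-fold lower number from compound 3 to compound 4 (0.50 log units; beyond the scatter), with 4-phenylbutyl in place of 2-methylprop-1-en-1-yl on a carbonyl carbon; the change at this one place thus moves the number beyond the usual scatter, towards stronger inhibition. The step from compound 1 to compound 4 cannot be read, as compound 1 has no number, so the exchange of 3,4-dimethoxyphenyl for 4-phenylbutyl, and with it the loss of the two hydrogen-bond acceptors, has neither a size nor a direction here. Nothing measured here accounts for the lower number of compound 4.

Still open, going by these compounds, is whether that lower number goes with the phenyl ring or with the length of the chain, which a pentyl chain, a 2-phenylethyl group or a 4-cyclohexylbutyl group on the same carbonyl carbon could help to separate. A 4-(3,4-dimethoxyphenyl)butyl group at this place could likewise show what the two methoxy groups do when the chain stays the same.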